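Adding a second hydroxy group to a cytotoxic quinolone

This account rests on a few compounds, and the source may have more. Where it says the series, first, only, none or still open, it means among the compounds named here.

Among the measured compounds shown here, compound 1 `Cc1cc(-c2c(F)cc3c(=O)c(Cc4ccccc4O)cn(C4CC4)c3c2F)cc(C)n1` is the weaker of the two compounds measured so far in a functional assay on P388 cells (Mus musculus) for cytotoxicity; a lower number here means a stronger inhibitor, a higher number a weaker inhibitor: compound 1 gives 670 nM. Its companion, compound 2 `Cc1cc(-c2c(F)cc3c(=O)c(Cc4ccc(O)cc4O)cn(C4CC4)c3c2F)cc(C)n1`, carries one extra hydroxy group on the benzyl ring, and in this assay compound 2 gives 210 nM, so that a 3.2-fold lower number from compound 1 to compound 2 (0.50 log units; beyond the scatter). The unmeasured compound 3 `Cc1cc(-c2c(F)cc3c(=O)c(Cc4cc(O)ccc4O)cn(C4CC4)c3c2F)cc(C)n1` also adds a single hydroxy group to compound 1, but at a different carbon of that ring: hydroxy in place of hydrogen on an aromatic carbon, turning the 2-hydroxyphenyl into a 2,5-dihydroxyphenyl. For the measured compounds named here, the only step that bears on this change is the one from compound 1 to compound 2, which was modest and beyond the scatter. The same kind of addition at a neighbouring position is therefore expected to give a step of similar size and direction, with a 2.6-fold lower number from compound 1 to compound 3 (0.41 log units; beyond the scatter). For compound 3 the estimated value in this assay is 260 nM, within a range of 100 nM to 700 nM.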

Compound 3, half-maximal inhibitory concentration: 360 nM
Compound 3: the middle estimate sits 1.4-fold (0.14 log units) below what was measured; low and high end bracket the measured number.
By their numbers in this assay, from the lowest: compounds 2, 3 and 1 (each within the scatter of the next, the first and the last beyond it).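

Placed para to a hydroxy group, the new hydroxy gives a 1.9-fold lower number from compound 1 to compound 3 (0.27 log units; within the scatter) in this assay, so at this carbon the addition cannot be told apart from the scatter, unlike the addition that led to compound 2. The comparison of the 2,4-dihydroxyphenyl with the 2,5-dihydroxyphenyl gives a 1.7-fold higher number from compound 2 to compound 3 (0.23 log units; within the scatter) and thus does not separate these two placements of the second hydroxy either. Nothing available offers an explanation for these numbers.

The compounds shown leave open whether a methoxy group or an amine at this same carbon would give a number clearly apart from that of compound 1. They also leave open whether a larger set of compounds carrying a second hydroxy group on this ring would show any real preference among its carbons.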